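The source may hold more compounds than are shown below. What is called first, only, known or untested is meant among the compounds shown, and "the series" means these compounds.

Working notes on the series, read in a functional assay (aorta) with Rattus norvegicus as the target; on this read-out lower numbers stand for stronger inhibition and higher numbers for weaker inhibition. Three analogues share one core and differ in a single group on an aromatic carbon. Chloro compound 1 `N#Cc1c(-c2ccccc2Cl)cc(-c2ccccc2O)nc1O` gives 30 nM. Bromo compound 2 `N#Cc1c(-c2ccccc2Br)cc(-c2ccccc2O)nc1O` gives 17000 nM. Methyl compound 3 `Cc1ccccc1-c1cc(-c2ccccc2O)nc(O)c1C#N` gives 1000 nM, the middle number of the three.

The next analogue is compound 4 `COc1ccccc1-c1cc(-c2ccccc2O)nc(O)c1C#N`, with methoxy in place of methyl on an aromatic carbon, ortho to a large group: methoxy in place of methyl on an aromatic carbon.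

Three measured steps change the group on that carbon: a 570-fold higher number from compound 1 to compound 2 (2.75 log units; beyond the scatter), a 33-fold higher number from compound 1 to compound 3 (1.52 log units; beyond the scatter) and a 17-fold lower number from compound 2 to compound 3 (1.23 log units; beyond the scatter). All three are large and beyond the scatter, so a large step cannot be excluded here. The two steps that reach compound 3 run in opposite directions, however, and none of the three involves methoxy. The data therefore give no direction for this change, and the central expectation in this assay is no step beyond the scatter, with a wide margin on both sides. The expected change is a 1.4-fold lower number from compound 3 to compound 4 (0.15 log units; within the scatter). Compound 4 is estimated at 700 nM, with an expected range of 80 nM to 6000 nM.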

Compound 4, half-maximal inhibitory concentration: 12 nM
Estimate against measurement, compound 4: 58-fold (1.77 log units) above; measured number outside the range, below it.
By their numbers in this assay, from the lowest: compound 4; then compound 1; then compound 3; then compound 2.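

In this assay, among the compounds shown here, this aromatic carbon accepts methoxy far better than the earlier steps could indicate: the change from methyl gives an 83-fold lower number from compound 3 to compound 4 (1.92 log units; beyond the scatter) and the change from bromo gives a 1400-fold lower number from compound 2 to compound 4 (3.15 log units; beyond the scatter) on the same carbon. Chloro, which held the lowest number until now, is also passed, though only modestly, with a 2.5-fold lower number from compound 1 to compound 4 (0.40 log units; beyond the scatter) as the step, so compound 4 has the lowest number of the four and a low number here is not confined to one group. No measurement available accounts for the wide gaps among these four groups.

Still open, on these data alone, is whether compound 1 and compound 4 reach their low numbers in the same way, since the order from lowest to highest, methoxy, chloro, methyl and bromo, does not by itself explain the spread. Ethoxy, hydroxyl or an amine on this carbon would show whether the low number extends beyond methoxy and chloro or whether the sharp rises seen with methyl and bromo are the more usual outcome at this position.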